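A few compounds are considered here, and "the series" means these few. Any claim that something is new, unique, unknown or untested is made for them only; others in the source may bear on it.

In a functional assay on HL-60 cells (Homo sapiens) for inhibition, read by MTT assay, with a stated time of 72 h (a lower number here means a stronger inhibitor, a higher number a weaker inhibitor), two compounds sharing one core have been measured so far. Compound 1 `COc1cccc(N2CCN(C(=O)c3oc(C)nc3-c3ccccc3F)CC2)c1` gives 56.1 nM, and compound 2 `Cc1nc(-c2ccccc2F)c(C(=O)N2CCN(c3cccc(Cl)c3)CC2)o1` gives 39.4 nM, so these two stand within the scatter of each other and cannot be ranked. Compound 3 `C=C(C)c1cccc(N2CCN(C(=O)c3oc(C)nc3-c3ccccc3F)CC2)c1` follows from compound 2 through (1-methylethenyl in place of chloro on an aromatic carbon), that is, 1-methylethenyl in place of chloro on an aromatic carbon, meta to a large group. Within the data shown here, only one measured step bears on this place, chloro in place of methoxy, a 1.4-fold lower number from compound 1 to compound 2 (0.15 log units; within the scatter), and it stays within the scatter. Among the measured compounds shown here, no compound carrying 1-methylethenyl has been measured, so this evidence is thin. No step beyond the scatter is expected in this assay, and no direction can be favoured. For compound 3 the estimated value is 45 nM, with an expected range of 15 nM to 130 nM. This estimate corresponds to an expected 1.1-fold higher number from compound 2 to compound 3 (0.06 log units; within the scatter).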

Compound 3, half-maximal inhibitory concentration: "not active" (no number reported)
Nothing numeric was reported for compound 3, and the estimate cannot be compared.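

In this assay, among these compounds, compound 3 is recorded only as "not active", without a number, so no step from compound 2 to compound 3 can be read. Nothing shown bears on this result. The compounds shown leave open how large the difference between 3-chlorophenyl and 3-(1-methylethenyl)phenyl is in this assay.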